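Extending the fluorinated chain of compound 2

A few compounds are considered here, and "the series" means these few. Any claim that something is new, unique, unknown or untested is made for them only; others in the source may bear on it.

In a functional assay on COLO 205 cells (Homo sapiens) for cytotoxicity, read by MTT assay, with a stated time of 24 h (on this read-out higher numbers stand for weaker inhibition and lower numbers for stronger inhibition), compound 1 `O=c1c2c(C(F)(F)F)cc(-c3ccccc3)nc2ncn1Cc1cn(CCC(F)(F)C(F)(F)C(F)(F)C(F)(F)C(F)(F)C(F)(F)C(F)(F)C(F)(F)F)nn1` gives 163 ug/mL as a measured number. In this assay compound 2 `Cc1nc2nc(-c3ccccc3)cc(C(F)(F)F)c2c(=O)n1Cc1cn(CCC(F)(F)C(F)(F)C(F)(F)C(F)(F)C(F)(F)C(F)(F)F)nn1` reads > 200 ug/mL as a limit, not a number. Compound 3 `Cc1nc2nc(-c3ccccc3)cc(C(F)(F)F)c2c(=O)n1Cc1cn(CCC(F)(F)C(F)(F)C(F)(F)C(F)(F)C(F)(F)C(F)(F)C(F)(F)C(F)(F)F)nn1` differs from compound 2 by one swap, 1,1,2,2,2-pentafluoroethyl in place of fluoro on a saturated chain carbon bound to two fluorine atoms and a saturated chain carbon. For the measured compounds named here, with compound 1 at 163 ug/mL as the only firm number, a small move toward stronger inhibition is expected, perhaps none beyond the scatter. The estimated at least 1.1-fold lower number from compound 2 to compound 3 (0.04 log units; that floor lies within the scatter) is that small step. Compound 3 is expected at 180 ug/mL within an estimated range of 90 ug/mL to 300 ug/mL and could again return only a limit.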

Compound 3, half-maximal inhibitory concentration: > 200 ug/mL
Compound 3 gave a limit, no number; the forecaster's own chance of this, stated with the estimate: 45%; middle value at least 1.1-fold (0.04 log units) from the limit.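

Compound 3 also returns a limit and not a number in this assay, so the step from compound 2 cannot be read: the limit of > 200 ug/mL in this assay, at which 2 of the 3 values shown sit. Compound 3 does connect to compound 1, which carries the same chain, through methyl in place of hydrogen on an aromatic carbon, and that swap gives an at least 1.2-fold higher number from compound 1 to compound 3 (0.08 log units; that floor lies within the scatter). Only this floor is known, so the methyl may or may not matter. On these data alone, how far chain length moves the read-out stays open, as does whether an amine or a carboxylic acid at the chain end would give a measured number.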